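Swapping the ether for a sulfonylated piperazine

This account rests on a few compounds, and the source may have more. Where it says the series, first, only, none or still open, it means among the compounds named here.

In an assay for inhibition of mitogen-activated protein kinase kinase kinase 14 (Homo sapiens), read by luminescence and ADP-Glo, with a stated time of 120 min, in the presence of a further agent that is not named here (a higher number here means a weaker inhibitor, a lower number a stronger inhibitor), compound 1 `C[C@H]1CN(c2ccc(C#CC(C)(O)c3nccs3)cc2Nc2ncnc3[nH]ccc23)CCN1` gives 69.2 nM and compound 2 `CC(O)(C#Cc1ccc(OC2CCOCC2)c(Nc2ncnc3[nH]ccc23)c1)c1nccs1` gives 112 nM. Of the two numbers, compound 2 has the higher one, yet the step of a 1.6-fold higher number from compound 1 to compound 2 (0.21 log units; within the scatter) lies within the scatter, so the two compounds cannot be told apart on this evidence.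

Compound 3 `CCS(=O)(=O)N1CCN(c2ccc(C#CC(C)(O)c3nccs3)cc2Nc2ncnc3[nH]ccc23)CC1` is the next step. It differs from compound 2 by 4-(ethylsulfonyl)piperazin-1-yl in place of (oxan-4-yl)oxy on an aromatic carbon. Within the data shown here, the only measured step that bears on this change is the one from compound 1 to compound 2, where a 3-methylpiperazin-1-yl gave way to (oxan-4-yl)oxy at the same aromatic carbon and the number moved by a 1.6-fold higher number from compound 1 to compound 2 (0.21 log units; within the scatter). Among the measured compounds shown here, compound 3 returns a piperazin-1-yl ring to that carbon, now carrying an ethylsulfonyl group, a substituent for which no measured compound offers a comparison.

Given that one small step, compound 3 is expected to land close to both measured compounds, with an expected step of a 1.4-fold lower number from compound 2 to compound 3 (0.15 log units; within the scatter) that stays within the scatter. The estimate for compound 3 in this assay is 80 nM, within a range from 30 nM to 250 nM.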

Compound 3, half-maximal inhibitory concentration: 8.22 nM
Compound 3: the middle estimate sits 9.7-fold (0.99 log units) above what was measured, and the stated range ends above it.
By their numbers in this assay, from the lowest: compound 3; then compounds 1 and 2 (each within the scatter of the next).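

At this aromatic carbon, ortho to a large group and para to a 3-hydroxy-3-(1,3-thiazol-2-yl)but-1-yn-1-yl group, placing 4-(ethylsulfonyl)piperazin-1-yl in place of (oxan-4-yl)oxy gives, in this assay, a 14-fold lower number from compound 2 to compound 3 (1.13 log units; beyond the scatter), and placing it in place of 3-methylpiperazin-1-yl gives an 8.4-fold lower number from compound 1 to compound 3 (0.93 log units; beyond the scatter). The earlier pair had not separated two groups at this carbon, whereas these steps show that the number does respond to the group there, and a piperazine ring alone does not go with the low number, since compound 1 carries one as well. Nothing measured here gives a reason for the lower number of compound 3.

The compounds shown leave open whether the sulfonyl is needed, or whether an acetyl group or a plain ethyl chain on the same piperazine ring would give a similar number, and how a longer chain in place of the ethyl on the sulfonyl would read. They also leave open whether the step would hold with a group other than the 3-hydroxy-3-(1,3-thiazol-2-yl)but-1-yn-1-yl group, which all three compounds share.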